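Lengthening the amine chain: from propyl to butyl

The source may hold more compounds than are shown below. What is called first, only, known or untested is meant among the compounds shown, and "the series" means these compounds.

Compound 1 `CCCNC(=C\C(=O)/C=C/c1ccc(O)c(OC)c1)/C=C/c1ccc(O)c(OC)c1` — 22700 nM
Compound 3 `CCC(C)NC(=C\C(=O)/C=C/c1ccc(O)cc1)/C=C/c1ccc(O)cc1` — 13000 nM
Compound 2 `COc1cc(/C=C/C(=O)/C=C(/C=C/c2ccc(OC(C)=O)c(OC)c2)NC2CCCCC2)ccc1OC(C)=O` — > 25000 nM

These three compounds share a core carrying an amine on a chain, and each was tested in a functional assay on HT-29 cells (Homo sapiens) for inhibition, read by MTT assay, with a stated time of 72 h; a higher number here means a weaker inhibitor, a lower number a stronger inhibitor. Compound 1 gives 22700 nM, the higher of the two numbers recorded. Compound 3 gives 13000 nM, which lies within the scatter of compound 1, so the two cannot be told apart. For compound 2 the assay returned only a limit, > 25000 nM; this is not a number but the edge of what the limit of > 25000 nM in this assay, at which 1 of the 3 values shown sits, can report.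

Compound 4 `CCCCNC(=C\C(=O)/C=C/c1ccc(O)c(OC)c1)/C=C/c1ccc(O)c(OC)c1` has not yet been tested. It differs from compound 1 in one place: methyl in place of hydrogen on a saturated chain carbon, three bonds along the chain from an amine nitrogen. The change is small and sits on the amine chain, away from the phenol-bearing arms. Among the measured compounds shown here, with no measured pair showing the effect of such a change, the step expected in this assay from compound 1 to compound 4 is none beyond the scatter: a 1.1-fold lower number from compound 1 to compound 4 (0.05 log units; within the scatter). Compound 4 is therefore expected to give about 20000 nM, most likely between 8000 nM and 50000 nM.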

Compound 4, half-maximal inhibitory concentration: 19700 nM
For compound 4 the middle estimate is 1.0-fold (0.01 log units) above the measured one; low and high end bracket the measured number.
By their numbers in this assay, from the lowest: compounds 3, 4 and 1 (each within the scatter of the next). At a limit, above all of these: compound 2.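

Among the compounds shown here, compounds 1 and 4 are the only pair here that differ in one place, so they give the first direct reading of the amine chain. In this assay, going from propyl to butyl, which puts methyl in place of hydrogen on a saturated chain carbon, three bonds along the chain from an amine nitrogen, gives a 1.2-fold lower number from compound 1 to compound 4 (0.06 log units; within the scatter). At this position, then, the added methyl leaves a change that cannot be told from the scatter, and the chain tolerates the extra carbon without a measurable shift in either direction.

From the compounds shown here alone, whether a much longer chain, such as octyl, or a chain ending in a hydroxyl or a carboxylic acid would move the number remains open. For compound 2 the assay gives only a limit: the limit of > 25000 nM in this assay, at which 1 of the 4 values shown sits.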